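Methyl Ether to Alcohol at the Assay Limit

This account rests on a few compounds, and the source may have more. Where it says the series, first, only, none or still open, it means among the compounds named here.

Three compounds have so far been examined in an assay on HEK293 cells for antagonist activity at Neuronal acetylcholine receptor; alpha3/beta4 (Rattus norvegicus), read by FLIPR, using a membrane potential dye; on this read-out lower numbers stand for stronger inhibition and higher numbers for weaker inhibition. Compound 1 `CCO[C@H]1CC=C2CCN(C)[C@H]2C1` returns only the limit > 300000 nM in this assay. Compound 2 `O[C@H]1CC[C@H]2CCN[C@H]2C1` likewise gives the limit > 300000 nM. Compound 3 `CO[C@H]1CC=C2CCN[C@H]2C1` also sits at the limit > 300000 nM, so no number is known for it, and it shares this position with the whole set: the limit of > 300000 nM in this assay, at which 3 of the 3 values shown sit. Compound 4 `O[C@H]1CC=C2CCN[C@H]2C1` differs from compound 3 by hydrogen in place of methyl on an oxygen on a saturated carbon. Among the compounds with values here, no step between two measured compounds exists to size this change, but every value so far is a limit, and compound 2, which carries the same hydroxy group, is among them. Accordingly the expected step, a step that the limit leaves unreadable from compound 3 to compound 4, is none beyond the scatter. Compound 4 is expected at 500000 nM, between 200000 nM and 2000000 nM, most likely reported again only as a limit.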

Compound 4, half-maximal inhibitory concentration: > 300000 nM
Compound 4: only a limit was reported (the forecaster's own chance of this, stated with the estimate: 90%); the middle value lies beyond the limit too.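

Compound 3 and compound 4 both return only a limit, so no step can be read for methoxy to hydroxy. The compounds shown leave open how strongly any of them actually inhibits, as all rest on one value: the limit of > 300000 nM in this assay, at which 4 of the 4 values shown sit.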